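The compounds below may be only part of what the source reports. "The series", "measured", "known", "first", "only" and "open" are said of these compounds alone.

Compound 1 `O=C(CBr)Nc1ccc(C(=O)/C=C/c2ccc(Cl)cc2)cc1`: 44%
Compound 2 `O=C(CBr)Nc1ccc(C(=O)/C=C/c2ccco2)cc1`: 30%

Of the compounds shown here, two have been tested in a functional assay on the whole organism (strain albino) for inhibition, with Rattus norvegicus as the target, read by paw edema, with stated times of 30 min and 1 h, at a dose of 100 mg/kg by the oral route; on this read-out lower numbers stand for less inhibition and higher numbers for more inhibition at the one dose given (going by the name of the read-out). Compound 1 gives 44% in this assay, and compound 2 gives 30%. Compound 1 thus stands highest of the two numbers; its nearest neighbour is compound 2, and the single step shown, a number 14 percentage points lower from compound 1 to compound 2 (beyond the scatter), puts furan-2-yl in place of 4-chlorophenyl on a double-bonded chain carbon bound to a double-bonded chain carbon.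

The next compound, compound 3 `CC(=O)c1ccc(OCC(=O)Nc2ccc(C(=O)/C=C/c3ccc(Cl)cc3)cc2)cc1`, has not been measured in this assay. Compared with compound 1 it differs by 4-acetylphenoxy in place of bromo on a saturated chain carbon bound to a carbonyl carbon. Within the data shown here, the measured step from compound 1 to compound 2 concerns a different place in the shared core, so no measured step bears directly on the exchange of bromo for 4-acetylphenoxy on a saturated chain carbon bound to a carbonyl carbon. With no guidance from the numbers, the expected step is a number 2 percentage points lower from compound 1 to compound 3 (within the scatter), that is, none beyond the scatter in either direction. Compound 3 is therefore estimated at 42%, with a range from 22% to 62%.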

Compound 3, a percentage reported as inhibition, in the whole organism at one dose (the size of the read-out at that dose, not a potency): 43%
Beside the measured number, compound 3's estimate is 1 percentage points below it; the measured number falls inside the stated range.
By their numbers in this assay, from the lowest: compound 2; then compounds 3 and 1 (each within the scatter of the next).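

Putting 4-acetylphenoxy in place of bromo on a saturated chain carbon bound to a carbonyl carbon gives, in this assay, a number 1 percentage points lower from compound 1 to compound 3 (within the scatter). Among these compounds, this is the first reading at this position, and it shows that, with 4-chlorophenyl held in place, a single bromine can give way to a group of 10 heavy atoms carrying a six-membered aromatic ring and the two numbers still stand within the scatter of each other, so in this pair the bromo is not required for the read-out at the one dose given. Among the compounds shown here, no evidence on hand accounts for this result, and the single pair offers no explanation of its own.

The compounds shown leave open whether the same exchange would hold with furan-2-yl in place of 4-chlorophenyl, since this position has been read only with the 4-chlorophenyl group. They also leave open how the read-out at this position would respond to a group of another kind, such as an amine like morpholine, a carboxylic acid or a plain phenoxy without the acetyl group.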